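Working notes: from compound 3 to compound 4

This account rests on a few compounds, and the source may have more. Where it says the series, first, only, none or still open, it means among the compounds named here.

Measured in a functional assay on NALM-6 cells (Homo sapiens) for cytotoxicity, with a stated time of 72 h (on this read-out higher numbers stand for an effect only at larger amounts of compound and lower numbers for an effect already at smaller amounts), each value being a limit of the assay:
- compound 1 `C=C[C@@](C)(/C=C/c1ccc(O)cc1)CCCO`: > 43400 nM
- compound 2 `C=C[C@@](C)(/C=C/c1ccc(O)cc1)CC/C=C/C(=O)OCC`: > 43400 nM
- compound 3 `C=C[C@@](C)(/C=C/c1ccc(O)cc1)CC/C=C(C)/C=N/N`: > 43400 nM

Compound 3 gives > 43400 nM, and this is a limit, not a number. It therefore has no readable position in the series, which so far shows only (the limit of > 43400 nM in this assay, at which 3 of the 3 values shown sit).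

The next compound is compound 4 `C=C[C@@](C)(/C=C/c1ccc(O)cc1)CC/C=C(\C)C(=O)OCC`. The change is a group of 5 heavy atoms (3 carbon, 2 oxygen; no ring) in place of a group of 3 heavy atoms (1 carbon, 2 nitrogen; no ring), on a double-bonded chain carbon bound to a double-bonded chain carbon and a saturated chain carbon.

Among the measured compounds shown here, three measured steps bear on this: a step that the two limits leave unreadable from compound 1 to compound 2, a step that the two limits leave unreadable from compound 1 to compound 3 and a step that the two limits leave unreadable from compound 2 to compound 3. None of them gives a size to carry over. All three also sit on a saturated chain carbon, not on a double-bonded chain carbon. Compound 2, with its 2-(ethoxycarbonyl)ethenyl group, gives > 43400 nM, again a limit. An ethoxycarbonyl-bearing chain has thus not yet produced a readable value in this assay. No step beyond the scatter is expected, in either direction, and another reading at the limit is the likeliest outcome.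

The expected change is a step that the limit leaves unreadable from compound 3 to compound 4. For compound 4 the estimate is 45000 nM, with an expected range of 20000 nM to 90000 nM.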

Compound 4, half-maximal effective concentration: > 43400 nM
Compound 4: only a limit was reported (the forecaster's own chance of this, stated with the estimate: 80%); the middle value does not contradict the limit.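

In this assay compound 4 gives > 43400 nM, which is again a limit and not a number, so the change from compound 3 to compound 4 cannot be read as a step. The compounds shown leave open whether any change on the shared core gives a readable value, as the series so far shows only: the limit of > 43400 nM in this assay, at which 4 of the 4 values shown sit.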